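Two Close Permeabilities and One Untested Ring Change

The source may hold more compounds than are shown below. What is called first, only, known or untested is meant among the compounds shown, and "the series" means these compounds.

Measured in an ADME assay on MDCK cells (Canis lupus familiaris) for permeability, in the apical to basolateral direction; on this read-out lower numbers stand for lower permeability and higher numbers for higher permeability:
- compound 1 `CC(C)C(CC1C(=O)NC(=O)N1C)c1ccc(-c2ccc3cccc(F)c3c2)[nH]c1=O` gives 17.6 10^-6 cm/s
- compound 2 `CC(C)[C@H](C[C@H]1SC(=O)NC1=O)c1ccc(-c2ccc3cccc(F)c3c2)[nH]c1=O` gives 17.6 10^-6 cm/s

On these numbers, compound 1 stands level with compound 2, and the two values lie within the usual scatter of repeated measurements. Compound 3 `CC(C)C(/C=C1/C(=O)NC(=O)N1C)c1ccc(-c2ccc3cccc(F)c3c2)[nH]c1=O` has not yet been measured. It keeps the core of compound 1 and changes one group, on a saturated chain carbon bound to an aromatic carbon and a saturated chain carbon: a group of 9 heavy atoms (5 carbon, 2 nitrogen, 2 oxygen; one five-membered non-aromatic ring with 2 hetero atoms) in place of a group of 9 heavy atoms (5 carbon, 2 nitrogen, 2 oxygen; one five-membered non-aromatic ring with 2 hetero atoms), on a saturated chain carbon bound to an aromatic carbon and a saturated chain carbon. The group that leaves is (3-methyl-2,5-dioxoimidazolidin-4-yl)methyl, and the group that enters has no common name. Within the data shown here, no measured pair shows what such a change does in this assay, so the expectation starts from compound 1 at 17.6 10^-6 cm/s and assumes no shift beyond the scatter, in either direction. The expected move is a 1.1-fold lower number from compound 1 to compound 3 (0.04 log units; within the scatter) and it is only an estimate. Compound 3 is estimated at 16 10^-6 cm/s (expected range 8 10^-6 cm/s to 28 10^-6 cm/s).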

Compound 3, apparent permeability: 14.1 10^-6 cm/s
The estimate for compound 3 lay 1.1-fold (0.05 log units) above the measured number; the measured number falls inside the stated range.
By their numbers in this assay, from the lowest: compounds 3, 1 and 2 (each within the scatter of the next).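

In this assay, putting the new ring group in place of (3-methyl-2,5-dioxoimidazolidin-4-yl)methyl gives a 1.2-fold lower number from compound 1 to compound 3 (0.10 log units; within the scatter). The entering group has the same heavy atoms, ring size, hydrogen-bond donor and acceptor counts as the leaving group but one more double bond outside aromatic rings, so this single pair shows that the added double bond, at this place on a saturated chain carbon, moves the number no further than the scatter. No supporting measurement speaks to why the number holds. This one pair cannot say whether the same would hold with the shared core changed. It also leaves open what a group of another kind at this place, such as an amine or a carboxylic acid, would do to the number.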